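The compounds below may be only part of what the source reports. "The series", "measured", "known", "first", "only" and "open" are said of these compounds alone.

In a functional assay on MDA-MB-231 cells (Homo sapiens) for antiproliferative activity, read by MTT assay, with a stated time of 48 h (on this read-out lower numbers stand for stronger inhibition and higher numbers for weaker inhibition), compound 2 `O=C(/C=C/c1ccccc1)Nc1cc2c(Nc3ccc(Cl)c(Cl)c3)ncnc2s1` gives 4400 nM, while compound 1 `COc1ccc(/C=C/C(=O)Nc2cc3c(Nc4ccc(Cl)c(Cl)c4)ncnc3s2)cc1` gives 16600 nM. The change between these two is methoxy in place of hydrogen on an aromatic carbon, and the step of a 3.8-fold higher number from compound 2 to compound 1 (0.58 log units; beyond the scatter) weakens inhibition modestly. Compound 3 `O=C(/C=C/c1ccccc1)Nc1cc2ncnc(Nc3ccc(F)c(Cl)c3)c2s1` is built on a different core; how its core differs from that of compound 2 is not broken down here. In this assay compound 3 gives 2100 nM, the lowest of the three numbers. Compound 4 `COc1ccc(/C=C/C(=O)Nc2cc3ncnc(Nc4ccc(F)c(Cl)c4)c3s2)cc1` has not yet been measured; it differs from compound 3 by methoxy in place of hydrogen on an aromatic carbon, the same change that turns compound 2 into compound 1. For the measured compounds named here, a step of similar size is expected, a 3.6-fold higher number from compound 3 to compound 4 (0.55 log units; beyond the scatter), because the earlier step of a 3.8-fold higher number from compound 2 to compound 1 (0.58 log units; beyond the scatter) is the only guide available. Compound 4 is therefore estimated at 7500 nM, with a likely range from 3000 nM to 20000 nM.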

Compound 4, half-maximal inhibitory concentration: 2600 nM
Compound 4: the middle estimate sits 2.9-fold (0.46 log units) above what was measured, outside the stated range (below it).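

In this assay, placing methoxy on the phenyl ring of compound 3 gives a 1.2-fold higher number from compound 3 to compound 4 (0.09 log units; within the scatter), so on this core the change has no clear effect on the number. The change therefore does not carry over in size between these two cores: the same change on two cores in this assay, a 3.8-fold higher number (0.58 log units; beyond the scatter) from compound 2 to compound 1 and a 1.2-fold higher number (0.09 log units; within the scatter) from compound 3 to compound 4, 3.0-fold (0.48 log units) apart, beyond the scatter of two such steps. This shows that a step measured on one core was a poor guide to the other here, but it does not show which part of the difference between compound 2 and compound 3 is responsible, and two pairs make no general rule.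

Going by these compounds, it remains open whether other groups in that place, such as a hydroxyl, an amine or a carboxylic acid, would also give steps that differ between the two cores. On these data alone, it also remains open how methoxy would behave on any further core.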